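Fluorine on the Anilino Ring of Compound 3

A few compounds are considered here, and "the series" means these few. Any claim that something is new, unique, unknown or untested is made for them only; others in the source may bear on it.

Three measured compounds share one core. Compound 1 `CCCNc1cccc(NC(=O)c2ccc(OCCC)cc2)n1` bears a propyl group on the nitrogen attached to the aromatic ring, and in an in vitro assay on HEK-tsA201 cells for antagonist activity at Neuronal acetylcholine receptor; alpha3/beta4 (Homo sapiens), read by fluorescence and calcium flux (a lower number here means a stronger inhibitor, a higher number a weaker inhibitor), compound 1 gives 12600 nM. Compound 2 `CCCCNc1cccc(NC(=O)c2ccc(OCCC)cc2)n1` bears a butyl group there, and in this assay compound 2 gives 77800 nM. Compound 3 `CCCOc1ccc(C(=O)Nc2cccc(Nc3ccccc3)n2)cc1` bears a phenyl group on that nitrogen. In this assay compound 3 reports only a limit of the assay, > 100000 nM. One of the three values sits at this limit (the limit of > 100000 nM in this assay, at which 1 of the 3 values shown sits), so compound 3 stands at the weak end of the set without a number of its own. The steps between the measured compounds read a 6.2-fold higher number from compound 1 to compound 2 (0.79 log units; beyond the scatter) and an at least 7.9-fold higher number from compound 1 to compound 3 (0.89 log units; beyond the scatter), while an at least 1.2-fold higher number from compound 2 to compound 3 (0.10 log units; that floor lies within the scatter).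

Compound 4 `CCCOc1ccc(C(=O)Nc2cccc(Nc3ccc(F)cc3)n2)cc1` differs from compound 3 by fluoro in place of hydrogen on an aromatic carbon. Among the measured compounds shown here, none of the measured steps changes a substituent on the phenyl ring; all of them alter the group on the nitrogen itself, so no recorded step bears directly on this change. Compound 3 already sits at the limit. Compound 4 is therefore expected to show no step beyond the scatter, a step that the limit leaves unreadable from compound 3 to compound 4. The estimate for compound 4 in this assay is 120000 nM, expected to lie between 40000 nM and 400000 nM, most likely again reported as a limit.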

Compound 4, half-maximal inhibitory concentration: > 100000 nM
Compound 4: no number, only a limit (the forecaster's own chance of this, stated with the estimate: 70%); the middle value does not contradict the limit.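

Fluoro in place of hydrogen, on an aromatic carbon para to a large group, does not bring the anilino compound inside the measurable range: in this assay compound 4 gives > 100000 nM, which is a limit of the assay and not a number. The step that the fluoro itself makes cannot be read, and any gain or loss it causes stays hidden because both compounds with an aromatic group on the nitrogen stand at the limit: the limit of > 100000 nM in this assay, at which 2 of the 4 values shown sit. Putting 4-fluorophenyl in place of propyl gives an at least 7.9-fold higher number from compound 1 to compound 4 (0.89 log units; beyond the scatter), while putting it in place of butyl gives an at least 1.2-fold higher number from compound 2 to compound 4 (0.10 log units; that floor lies within the scatter), so only the change from propyl reads as a step beyond the scatter.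

The compounds shown leave open whether any other group on that phenyl ring, such as methoxy or chlorine, would give a value inside the range of the assay. They also leave open how a shorter chain such as ethyl, or a benzyl group, on the nitrogen would compare with propyl, and whether fluoro would change the value on a compound that has a measured number.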